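The source may report more compounds than this note shows. Statements on the series, on what has been measured and on what is new or still open speak of the compounds shown alone.

In an assay for binding affinity to dual specificity mitogen-activated protein kinase kinase 4 (Homo sapiens), read by KINOMEscan, tested at 100 nM (on this read-out lower numbers stand for a stronger effect and higher numbers for a weaker effect at the one concentration tested), compound 1 `CCCS(=O)(=O)Nc1ccc(F)c(C(=O)c2n[nH]c3ncc(-c4cccc(N(C)C)c4)cc23)c1F` gives 26%. Compound 2 `CCCS(=O)(=O)Nc1ccc(F)c(C(=O)c2n[nH]c3ncc(-c4ccc(C)c(C)c4)cc23)c1F` keeps the same core and differs from compound 1 only in the group on an aromatic carbon of the fused ring system; in this assay compound 2 gives 20%. For the measured compounds named here, the single measured step, a number 6 percentage points lower from compound 1 to compound 2 (within the scatter), is too small to stand out from the usual scatter of repeated measurements. Going by the values given here, of the two numbers known so far, that of compound 2 is nominally the lower, yet the gap to compound 1 lies within the scatter, so the two compounds cannot really be told apart.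

Compound 3 `CCCS(=O)(=O)Nc1ccc(F)c(C(=O)c2n[nH]c3ncc(-c4ccc(F)cc4C)cc23)c1F` alters the same position once more: 4-fluoro-2-methylphenyl in place of 3,4-dimethylphenyl on an aromatic carbon. Among the compounds with values here, no measured step involves 4-fluoro-2-methylphenyl, so the only guide is the step from compound 1 to compound 2, which also exchanged one group for another at this aromatic carbon and stayed within the scatter. The expected step of a number 5 percentage points higher from compound 2 to compound 3 (within the scatter) is therefore small, with no clear direction, and not beyond the scatter. Compound 3 is estimated to give 25% in this assay, within a range from 10% to 45%.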

Compound 3, a percentage reported as activity, at one concentration (the size of the read-out at that concentration, not a potency): 14%
Compound 3: the middle estimate sits 11 percentage points above what was measured; low and high end bracket the measured number.
By their numbers in this assay, from the lowest: compounds 3, 2 and 1 (each within the scatter of the next, the first and the last beyond it).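

In this assay, this aromatic carbon now gives its first step beyond the scatter, a number 12 percentage points lower from compound 1 to compound 3 (beyond the scatter), so exchanging 3-(dimethylamino)phenyl for 4-fluoro-2-methylphenyl has a modest but readable effect. The other new step, a number 6 percentage points lower from compound 2 to compound 3 (within the scatter), means that 3,4-dimethylphenyl and 4-fluoro-2-methylphenyl cannot be told apart here, and compound 2 cannot be clearly separated from either of the other two compounds. Nothing available explains why the groups at this position differ in this way.

As far as these compounds go, all three groups at this position are substituted phenyl rings, so it remains open whether an amine, a carboxylic acid or a longer carbon chain placed directly on this aromatic carbon would keep a low number in this binding read-out. From the compounds shown here alone, it also remains open how much the fluorine and the methyl group of 4-fluoro-2-methylphenyl each contribute, and whether a plain unsubstituted phenyl ring would stand with compound 3 or with compound 1.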